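Carbamates of propargyl- and benzyl-substituted piperidines

The compounds below may be only part of what the source reports. "The series", "measured", "known", "first", "only" and "open" are said of these compounds alone.

Compound 1 `O=C(Nc1ccccc1)OC1CCCN(Cc2ccccc2)C1`: 33300 nM
Compound 2 `C#CCN1CCC(OC(=O)Nc2ccc(C(C)C)cc2)CC1`: 178 nM
Compound 3 `C#CCN1CCC(COC(=O)Nc2ccc(C(C)C)cc2)CC1`: 316 nM

In an assay on BTI-TN-5B1-4 cells for inhibition of Amine oxidase [flavin-containing] B (Homo sapiens), read by fluorescence and Amplex Red, using microsomes, with a stated time of 15 min (on this read-out higher numbers stand for weaker inhibition and lower numbers for stronger inhibition), compound 3 gives the second highest of the three numbers. Its nearest neighbour is compound 2, which in this assay gives 178 nM, a gap that stays within the scatter, so the two cannot be ranked against each other. Furthest away is compound 1, which in this assay gives 33300 nM, a gap well beyond the scatter; compound 1, however, differs from compound 3 in more than one place, so no single change accounts for that gap.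

Compound 4 `CC(C)c1ccc(NC(=O)OCC2CCN(Cc3ccccc3)CC2)cc1` has not yet been measured. It differs from compound 3 in one place: phenyl in place of ethynyl on a saturated chain carbon bound to an amine nitrogen in a ring. Within the data shown here, no measured pair shows this change alone. Among the measured compounds shown here, compound 1, the only measured compound carrying a benzyl on the ring nitrogen, is weak, but it also lacks the isopropyl and carries its carbamate on a different ring position. The step from compound 3 to compound 4 is therefore expected to be a sizeable move toward weaker inhibition, a 13-fold higher number from compound 3 to compound 4 (1.10 log units; beyond the scatter), with wide uncertainty. Compound 4 is estimated at 4000 nM, in a range from 800 nM to 20000 nM.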

Compound 4, half-maximal inhibitory concentration: > 100000 nM
Compound 4: only a limit was reported; the forecaster's own chance of this, stated with the estimate: 10%; middle value at least 25-fold (1.39 log units) from the limit.
By their numbers in this assay, from the lowest: compounds 2 and 3 (each within the scatter of the next); then compound 1. At a limit, above all of these: compound 4.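

In this assay, phenyl in place of ethynyl on a saturated chain carbon bound to an amine nitrogen in a ring, the difference that also reads as propargyl to benzyl, gives an at least 310-fold higher number from compound 3 to compound 4 (2.50 log units; beyond the scatter), a large step beyond the scatter. The result for compound 4 is a limit and not a number: the limit of > 100000 nM in this assay, at which 1 of the 4 values shown sits. Among these compounds, this is the first measured pair that shows the change alone: compound 1 differs from compound 3 in more than one place, whereas here everything else in the structure stays the same, and this one exchange is enough to take inhibition out to that limit.

The compounds shown leave open whether the step follows the loss of the triple bond or the arrival of the phenyl ring, a question that a propyl or a cyclohexylmethyl group at the same place would help to separate. They also leave open whether the same exchange would have a comparable effect on the core of compound 2, and whether a pyridylmethyl group would behave like the benzyl.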